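The source may hold more compounds than are shown below. What is called first, only, known or untested is meant among the compounds shown, and "the series" means these compounds.

Of the compounds shown here, two have been measured so far in a physicochemical assay for solubility, read by HPLC, with a stated time of 4 h, at pH 7; a lower number here means a less soluble compound, a higher number a more soluble compound. Compound 1 `C[C@]1(COc2ccc(S(=O)(=O)N3CCOCC3)cc2)Cn2cc([N+](=O)[O-])nc2O1` gives 20 ug/mL in this assay. Compound 2 `CCOc1ccc(NC(=O)Nc2ccc(OC[C@@]3(C)Cn4cc([N+](=O)[O-])nc4O3)cc2)cc1` gives 6.66 ug/mL in this assay, the lower of the two numbers, and the gap between compound 2 and compound 1 lies beyond the usual scatter of repeated measurements.

Compound 3 `Cc1ccc(NC(=O)Nc2ccc(OC[C@@]3(C)Cn4cc([N+](=O)[O-])nc4O3)cc2)cc1` has not yet been measured. It differs from compound 2 in one place: methyl in place of ethoxy on an aromatic carbon. Among the compounds with values here, no measured pair of compounds shows this same change, so there is no measured step to set its size from. The group that leaves and the group that enters are both small and uncharged, so the step from compound 2 to compound 3 is expected to be small, a 1.2-fold lower number from compound 2 to compound 3 (0.08 log units; within the scatter), with no change beyond the scatter in either direction. Compound 3 is therefore estimated to give 5.5 ug/mL in this assay, within a range of 2.2 ug/mL to 14 ug/mL.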

Compound 3, solubility: < 1 ug/mL
Compound 3 was reported as a limit; the forecaster's own chance of this, stated with the estimate: 5%; at least 5.5-fold (0.74 log units) between middle value and limit.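

This position, on a six-membered aromatic ring of carbon only and para to a large group, is more sensitive in this assay than the small size of the swap might suggest: replacing ethoxy with methyl gives an at least 6.6-fold lower number from compound 2 to compound 3 (0.82 log units; beyond the scatter). For compound 3 the reading < 1 ug/mL is a limit, not a number. The step is therefore open-ended on its low side, and its size rests on a single reading: the limit of < 1 ug/mL in this assay, at which 1 of the 3 values shown sits.

On these data alone, whether an ethyl group, a methoxy group or an amine at this position would read closer to compound 2 or to compound 3 remains open. This single pair gives no measured reason for the step and cannot show whether the same change would have a similar effect in other compounds.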